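Extending Compound 3 at the Phenyl on Nitrogen

The source may hold more compounds than are shown below. What is called first, only, known or untested is meant among the compounds shown, and "the series" means these compounds.

compound 1, `CCCCCn1nc(C(C)(C)C)cc1CNC(=O)C(C)c1ccc(NS(C)(=O)=O)c(F)c1`: 50.2 nM
compound 2, `CCCCCCn1nc(C(C)(C)C)cc1CNC(=O)C(C)c1ccc(NS(C)(=O)=O)c(F)c1`: 27.7 nM
compound 3, `CC(C(=O)NCc1cc(C(C)(C)C)nn1-c1ccccc1)c1ccc(NS(C)(=O)=O)c(F)c1`: 8 nM

In an assay on CHO cells for antagonist activity at transient receptor potential cation channel subfamily V member 1 (Homo sapiens), read by FLIPR and calcium flux, with a stated time of 6 min (a higher number here means a weaker inhibitor, a lower number a stronger inhibitor), compound 3 gives the lowest number of the three. Replacing the alkyl chain on the aromatic nitrogen by phenyl brought a 6.3-fold lower number from compound 1 to compound 3 (0.80 log units; beyond the scatter) and a 3.5-fold lower number from compound 2 to compound 3 (0.54 log units; beyond the scatter), while lengthening the chain itself gave only a 1.8-fold lower number from compound 1 to compound 2 (0.26 log units; within the scatter). Compound 4, `Cc1ccc(/C=C/c2ccc(-n3nc(C(C)(C)C)cc3CNC(=O)C(C)c3ccc(NS(C)(=O)=O)c(F)c3)cc2)cc1`, keeps that phenyl and adds to it: 2-(4-methylphenyl)ethenyl in place of hydrogen on an aromatic carbon. For the measured compounds named here, no measured step touches this position, so the earlier steps say only that the phenyl region tolerates and rewards change. The expectation for compound 4 is therefore a step near zero, a 1.3-fold higher number from compound 3 to compound 4 (0.10 log units; within the scatter), with wide uncertainty. Compound 4 is estimated at 10 nM, ranging from 2 nM to 50 nM.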

Compound 4, inhibition constant: 819 nM
The estimate for compound 4 lay 82-fold (1.91 log units) below the measured number; the whole stated range lies below it.
By their numbers in this assay, from the lowest: compound 3; then compounds 2 and 1 (each within the scatter of the next); then compound 4.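

Putting 2-(4-methylphenyl)ethenyl in place of hydrogen on an aromatic carbon of the phenyl, para to a large group, gave a 100-fold higher number from compound 3 to compound 4 (2.01 log units; beyond the scatter). For the compounds shown here, the gain seen on going from an alkyl chain to phenyl therefore does not extend to this addition, and the position is far less forgiving than the earlier steps could show. Nothing available explains this loss.

Still open, as far as these compounds go, is whether any group on this carbon costs as much, or only one this large. A methyl, a chlorine or an amine there would begin to separate those cases.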